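The source may hold more compounds than are shown below. What is called first, only, known or untested is meant among the compounds shown, and "the series" means these compounds.

Measured in a functional assay on HT-29 cells (Homo sapiens) for antiproliferative activity, read by MTT assay, with a stated time of 72 h; a higher number here means a weaker inhibitor, a lower number a stronger inhibitor:
- compound 1 `Nc1nc(N)c2cc(CSC(=S)N3CCN(C4CCCCC4)CC3)ccc2n1`: 4050 nM
- compound 2 `Nc1nc(N)c2cc(CSC(=S)N3CCN(c4ccccc4)CC3)ccc2n1`: 2760 nM
- compound 3 `Cc1ccc(N2CCN(C(=S)SCc3ccc4nc(N)nc(N)c4c3)CC2)c(C)c1`: 2970 nM

Compound 3 stands within the scatter of both other compounds: a 1.1-fold higher number from compound 2 to compound 3 (0.03 log units; within the scatter) and a 1.4-fold lower number from compound 1 to compound 3 (0.13 log units; within the scatter). Next comes compound 4 `Nc1nc(N)c2cc(CSC(=S)N3CCN(c4ccc(F)cc4)CC3)ccc2n1`, with the change 4-fluorophenyl in place of 2,4-dimethylphenyl on an amine nitrogen in a ring. All three measured steps replace the group at this same place. Besides the two above, a 1.5-fold lower number from compound 1 to compound 2 (0.17 log units; within the scatter) also stays within the scatter. Among the compounds with values here, no fluorine-bearing compound has been measured yet, so this comparison is only indirect. No step beyond the scatter is expected in this assay. The expected result is a 1.1-fold lower number from compound 3 to compound 4 (0.04 log units; within the scatter). Compound 4 is expected at 2700 nM, with an estimated range of 1400 nM to 5000 nM.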

Compound 4, half-maximal inhibitory concentration: 2050 nM
For compound 4 the middle estimate is 1.3-fold (0.12 log units) above the measured one; measured number inside the range.
By their numbers in this assay, from the lowest: compounds 4, 2, 3 and 1 (each within the scatter of the next).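

In this assay, within the data shown here, the first fluorine-bearing group on this amine nitrogen in a ring still separates nothing: replacing 2,4-dimethylphenyl gives a 1.4-fold lower number from compound 3 to compound 4 (0.16 log units; within the scatter) and fluoro in place of hydrogen on an aromatic carbon gives a 1.3-fold lower number from compound 2 to compound 4 (0.13 log units; within the scatter) while replacing cyclohexyl gives a 2.0-fold lower number from compound 1 to compound 4 (0.30 log units; within the scatter) in the same way. Aromatic and saturated groups at this place therefore remain indistinguishable across the four compounds. Nothing available accounts for this flat result. On these data alone, whether a carboxylic acid, a primary amine or a longer chain on this nitrogen would give a step beyond the scatter stays open. As far as these compounds go, the effect of changes to the shared core also stays open.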